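Nitro in place of hydrogen: from compound 1 to compound 3

The source may hold more compounds than are shown below. What is called first, only, known or untested is meant among the compounds shown, and "the series" means these compounds.

Compound 1 `CC1=C(/C=C/C(=O)/C=C/c2ccccc2)C(C)(C)CCC1` is measured in a functional assay on MCF7 cells (Homo sapiens) for cytotoxicity, read by sulforhodamine B assay, with a stated time of 48 h (a higher number here means a weaker inhibitor, a lower number a stronger inhibitor), where compound 1 gives 10600 nM, the higher of the two numbers shown, with compound 2 within the scatter of it. Compound 2 `CC1=C(/C=C/C(=O)/C=C/c2ccc([N+](=O)[O-])cc2)C(C)(C)CCC1` in this assay gives 5500 nM; the step of a 1.9-fold lower number from compound 1 to compound 2 (0.28 log units; within the scatter) puts a nitro in place of hydrogen on an aromatic carbon and stays within the scatter. Compound 3 `CC1=C(/C=C/C(=O)/C=C/c2ccccc2[N+](=O)[O-])C(C)(C)CCC1` is not yet measured. It differs from compound 1 by nitro in place of hydrogen on an aromatic carbon, the nitro sitting ortho to a large group. Going by the values given here, the only step that bears on this change is the one from compound 1 to compound 2, and it was small. The expected change in this assay is therefore small too, a 1.4-fold lower number from compound 1 to compound 3 (0.15 log units; within the scatter), with no direction beyond the scatter claimed. Compound 3 is estimated at 7500 nM, with a range from 3000 nM to 19000 nM.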

Compound 3, half-maximal inhibitory concentration: 10100 nM
Compound 3: the middle estimate sits 1.3-fold (0.13 log units) below what was measured, within the range that was stated.
By their numbers in this assay, from the lowest: compounds 2, 3 and 1 (each within the scatter of the next).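

With the nitro ortho to a large group, the reading in this assay is a 1.0-fold lower number from compound 1 to compound 3 (0.02 log units; within the scatter) and gives a second nitro-for-hydrogen step on the aromatic ring of the shared core. Going by these compounds alone, neither this step nor the one to compound 2 leaves the scatter, so in these two placements the nitro does not separate either compound from compound 1. No measurement at hand bears on the reason for this result.

On these data alone, it remains open whether an amine or a carboxylic acid on the same aromatic carbon would give a step beyond the scatter in this assay when set against compound 1. As far as these compounds go, it also remains open whether a methoxy group or a longer chain in that place would give such a step.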